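The source may report more compounds than this note shows. Statements on the series, on what has been measured and on what is new or still open speak of the compounds shown alone.

In a functional assay on PC-3 cells (Homo sapiens) for antiproliferative activity, read by CCK-8 assay, with a stated time of 6 days (on this read-out lower numbers stand for stronger inhibition and higher numbers for weaker inhibition), compound 1 `CCN(c1ccc(C#N)c(Cl)c1)c1cc(-n2cnc3ccccc32)ccc1C` gives 8160 nM and compound 3 `CCN(c1ccc(C#N)c(Cl)c1)c1cc(-n2cccn2)ccc1C` gives 15700 nM as its value. The gap between them, a 1.9-fold higher number from compound 1 to compound 3 (0.28 log units; within the scatter) in size, gives the two no order. Compound 2 `CCN(c1ccc(C#N)c(Cl)c1)c1cc(-c2ccco2)ccc1C` reads > 30000 nM as a limit of the assay, not a number.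

The next change, to compound 4 `CCN(c1ccc(C#N)c(Cl)c1)c1cc(-c2ccoc2)ccc1C`, is furan-3-yl in place of 1H-pyrazol-1-yl on an aromatic carbon on the shared core: furan-3-yl in place of 1H-pyrazol-1-yl on an aromatic carbon. Compound 2 is the nearest comparison, as the furan-2-yl member. The steps touching it are an at least 1.9-fold lower number from compound 2 to compound 3 (0.28 log units; that floor lies within the scatter) for the exchange with the pyrazole and an at least 3.6-fold higher number from compound 1 to compound 2 (0.56 log units; beyond the scatter) for the exchange with the benzimidazole. On that basis, a furan in this place is expected to give a somewhat higher number than the pyrazole, with the step small and probably inside the scatter. The expected step is a 1.4-fold higher number from compound 3 to compound 4 (0.15 log units; within the scatter) in size. Compound 4 is estimated at 22000 nM with an expected range from 11000 nM to 42000 nM and a fair chance of a read-out only as a limit.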

Compound 4, half-maximal inhibitory concentration: > 30000 nM
Compound 4: only a limit was reported (the forecaster's own chance of this, stated with the estimate: 40%); middle value at least 1.3-fold (0.13 log units) from the limit.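

In this assay, moving the furan attachment from furan-2-yl to furan-3-yl gives no readable value at this position, para to a methyl group: like compound 2, compound 4 is reported only as a limit of the assay. Replacing the benzimidazole gives an at least 3.6-fold higher number from compound 1 to compound 4 (0.56 log units; beyond the scatter), in line with the furan-2-yl result, while replacing the pyrazole gives an at least 1.9-fold higher number from compound 3 to compound 4 (0.28 log units; that floor lies within the scatter), a floor that sets no firm order. The step between the two furans cannot be read, and the series now rests in part on a single ceiling: the limit of > 30000 nM in this assay, at which 2 of the 4 values shown sit.

So far the two nitrogen-linked rings give numbers and the two carbon-linked furans give limits, but these four compounds cannot separate the linking atom from the ring itself. As far as these compounds go, whether an imidazole, an open-chain amine or a carboxylic acid at this place would give a readable number remains open.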